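This account rests on a few compounds, and the source may have more. Where it says the series, first, only, none or still open, it means among the compounds named here.

Working notes on the series, read in a functional assay on A-375 cells (Homo sapiens) for cytotoxicity, read by MTT assay, with a stated time of 72 h; a higher number here means a weaker inhibitor, a lower number a stronger inhibitor. Compound 1 `O=C1c2c[n+]([O-])c3ccccc3c2C(=O)c2c1c1ccccc1n2CCCCn1ccnc1` gives 350 nM, and compound 2 `O=C1c2c[n+]([O-])c3ccccc3c2C(=O)c2c1c1ccccc1n2CCN1CCCCC1` gives 180 nM. Within the data shown here, compound 2 therefore stands level with compound 1, the only other measured compound, since the two values lie within the scatter of each other.

Compound 3 `CN1CCN(CCCCCn2c3c(c4ccccc42)C(=O)c2c[n+]([O-])c4ccccc4c2C3=O)CC1` is not yet measured. It has 3-(4-methylpiperazin-1-yl)propyl in place of piperidin-1-yl, on a saturated chain carbon, two bonds along the chain from an aromatic nitrogen: 3-(4-methylpiperazin-1-yl)propyl in place of piperidin-1-yl on a saturated chain carbon, two bonds along the chain from an aromatic nitrogen.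

Among the measured compounds shown here, one measured step bears on this change, a 1.9-fold lower number from compound 1 to compound 2 (0.29 log units; within the scatter). It exchanges a group at the same place and stays within the scatter, but it is a single step and a different exchange. For the measured compounds named here, no measured compound carries the entering group, so the data give no direction for the change. No step beyond the scatter is expected in this assay, and the estimated step is a 1.4-fold higher number from compound 2 to compound 3 (0.14 log units; within the scatter). For compound 3 the expected value is 250 nM, with an estimated range of 80 nM to 750 nM.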

Compound 3, half-maximal inhibitory concentration: 1710 nM
The estimate for compound 3 lay 6.8-fold (0.84 log units) below the measured number; the whole stated range lies below it.
By their numbers in this assay, from the lowest: compounds 2 and 1 (each within the scatter of the next); then compound 3.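

In this assay, this position now shows a step beyond the scatter: a 9.5-fold higher number from compound 2 to compound 3 (0.98 log units; beyond the scatter), with 3-(4-methylpiperazin-1-yl)propyl in place of piperidin-1-yl on a saturated chain carbon, two bonds along the chain from an aromatic nitrogen. The comparison with the imidazole-bearing compound runs the same way, a 4.9-fold higher number from compound 1 to compound 3 (0.69 log units; beyond the scatter), whereas the earlier exchange gave only a 1.9-fold lower number from compound 1 to compound 2 (0.29 log units; within the scatter), so the chain end of the shared core can no longer be read as indifferent to substitution in this assay. The change replaces 2-(piperidin-1-yl)ethyl with 5-(4-methylpiperazin-1-yl)pentyl, altering chain and ring together, and nothing measured on these compounds assigns the step to either part.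

Still open, going by these compounds, is whether the chain or the ring carries the step, a question that a 2-(4-methylpiperazin-1-yl)ethyl group and a 5-(piperidin-1-yl)pentyl group on the same core would separate. Also open, on these data alone, is how an open-chain tertiary amine, such as dimethylamino at the end of the ethyl chain, would compare with compound 2.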